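From Compound 2 to Compound 3: One Group Exchanged

This account rests on a few compounds, and the source may have more. Where it says the series, first, only, none or still open, it means among the compounds named here.

Of the compounds shown here, two have so far been tested in a functional assay on PC-9 cells (Homo sapiens) for inhibition, read by MTT assay, with a stated time of 72 h; a lower number here means a stronger inhibitor, a higher number a weaker inhibitor. Compound 1 `CCCCCc1c(C)nc2nc(SCc3ccc(Cl)cc3)nn2c1Nc1cc(-c2ccccc2)[nH]n1` returned only a limit, > 50000 nM, and not a number. Among the measured compounds shown here, compound 2 `Cc1cc(Nc2ccn(Cc3csc4ccc(Cl)cc34)n2)n2nc(SCc3ccc(Br)cc3)nc2n1` gave 4350 nM, which makes it the only compound with a true number in this assay.

The next compound to be tested is compound 3 `Cc1ccc(Cn2ccc(Nc3cc(C)nc4nc(SCc5ccc(Br)cc5)nn34)n2)cc1`, which differs from compound 2 at a single place. On a saturated chain carbon bound to an aromatic nitrogen, 4-methylphenyl stands in place of 5-chloro-1-benzothiophen-3-yl (4-methylphenyl in place of 5-chloro-1-benzothiophen-3-yl on a saturated chain carbon bound to an aromatic nitrogen). The shared core and the rest of the molecule stay the same.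

For the measured compounds named here, no measured pair of compounds shows this exchange, so the data give no direct guide to its size. The expectation therefore starts from compound 2 at 4350 nM and allows for a wide margin on either side. The estimated step of a 1.6-fold higher number from compound 2 to compound 3 (0.21 log units; within the scatter) is expected to be a modest weakening in this assay, not far beyond the usual scatter. For compound 3 the expected value is 7000 nM, with an estimated range of 2000 nM to 25000 nM.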

Compound 3, half-maximal inhibitory concentration: > 50000 nM
Compound 3 gave a limit, no number; the forecaster's own chance of this, stated with the estimate: 15%; middle value at least 7.1-fold (0.85 log units) away from the limit.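

In this assay, among the compounds shown here, the saturated chain carbon bound to an aromatic nitrogen turns out to be a place where the attached group matters, something the earlier compounds could not show, as no step linked compound 1 and compound 2. For the compounds shown here, exchanging 5-chloro-1-benzothiophen-3-yl for 4-methylphenyl at this place gives an at least 11-fold higher number from compound 2 to compound 3 (1.06 log units; beyond the scatter), the first step that can be read, and it lies beyond the scatter. Compound 3 reaches only a limit of the assay, > 50000 nM, so the step is a bound and not a measured size: the limit of > 50000 nM in this assay, at which 2 of the 3 values shown sit.

The exchange removes the chlorine, the sulfur and the five-membered ring together, so the compounds shown do not tell which of these changes accounts for the weaker result. On these data alone, a 4-chlorobenzyl or a naphthalen-2-ylmethyl group on the same nitrogen would begin to separate them, and whether any group here can give a lower number than compound 2 at 4350 nM remains open.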